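The source may hold more compounds than are shown below. What is called first, only, known or untested is meant among the compounds shown, and "the series" means these compounds.

Measured so far:
Compound 1, `CCN(CC)c1ccc(/C=N/NC(=O)c2ccccc2)c(O)c1`: 1100 nM
Compound 2, `COc1ccc(C(=O)N/N=C/c2cc(C(C)(C)C)ccc2O)cc1`: > 100000 nM

In a functional assay on MRC5 cells (Homo sapiens) for cytotoxicity, read by colorimetric assay and MTT assay (on this read-out lower numbers stand for higher toxicity in this test and higher numbers for lower toxicity in this test), compound 1 gives 1100 nM. Compound 2 reaches only the limit of the test: in this assay compound 2 gives > 100000 nM, which is a limit and not a number. Of the two values shown, one sits at that limit (the limit of > 100000 nM in this assay, at which 1 of the 2 values shown sits), so compound 2 stands at the low-toxicity end of what the test can report. Compound 3, `CC(C)(C)c1ccc(O)c(/C=N/NC(=O)c2ccccc2)c1`, has not yet been measured. It differs from compound 2 in a single place: hydrogen in place of methoxy on an aromatic carbon. No step between two measured compounds is shown, so there is no measured pair to gauge this change against. Compound 3 is expected to stay near the limit, and the step of a number no higher from compound 2 to compound 3 (the limit leaves the size open) is estimated to be small, within the usual scatter. Compound 3 is estimated at 100000 nM in this assay, within 25000 nM to 300000 nM.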

Compound 3, half-maximal cytotoxic concentration: 2600 nM
The estimate for compound 3 lay 38-fold (1.59 log units) above the measured number; the whole stated range lies above it.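

In this assay, replacing methoxy with hydrogen, so that 4-methoxyphenyl becomes phenyl, gives an at least 38-fold lower number from compound 2 to compound 3 (1.58 log units; beyond the scatter) and thus markedly higher toxicity in this test. This shows that the place on the aromatic ring para to a large group is not indifferent here: one small change is enough to move a compound from the low-toxicity end of the test to a value that can be read as a number. On these data alone, the true size of the step stays open, since the value for compound 2 is a limit and not a number: (the limit of > 100000 nM in this assay, at which 1 of the 3 values shown sits).

As far as these compounds go, only methoxy and hydrogen are seen at this place, so it remains open where an ethoxy group, a chlorine atom or an amine would fall. A single pair also cannot show whether the same change would act alike on another core.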